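A change of ring isomer at the piperidine-bound heteroaryl

The compounds below may be only part of what the source reports. "The series", "measured", "known", "first", "only" and "open" are said of these compounds alone.

Measured compounds:
compound 1 `COc1cnc(N2CCC(CCCNc3ccc4c(c3)OCC4=O)CC2)nc1`: 60 nM
compound 2 `CC(C)c1nc(N2CCC(CCCNc3ccc4c(c3)OCC4=O)CC2)no1`: "not determined" (no result reported)

In a functional assay on CHO-K1 cells for agonist activity at Glucose-dependent insulinotropic receptor (Mus musculus), read by HTRF and cAMP accumulation, with a stated time of 30 min (a higher number here means that more compound is needed for the effect, a lower number that less compound is needed), compound 1 gives 60 nM. Compound 2 carries the same core, but on the amine nitrogen in the ring it bears a 5-isopropyl-1,2,4-oxadiazol-3-yl group in place of the group of compound 1; in this assay compound 2 is recorded as "not determined" (no result reported), so it stands nowhere on the numbers shown, and nothing can be said about how it compares with compound 1.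

Compound 3 `CC(C)c1nnc(N2CCC(CCCNc3ccc4c(c3)OCC4=O)CC2)o1` is the next compound. It differs from compound 2 in one place: 5-isopropyl-1,3,4-oxadiazol-2-yl in place of 5-isopropyl-1,2,4-oxadiazol-3-yl on an amine nitrogen in a ring. The two have the same atoms, joined differently, so this is an exchange of one ring isomer for another on the same anchor.

Compound 2 has no number in this assay. Within the data shown here, no step from compound 2 to compound 3 can be sized, and no direction beyond the scatter can be claimed. With only compound 1 as a reference in this assay, the author expects compound 3 to give 150 nM, within a range from 30 nM to 800 nM.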

Compound 3, half-maximal effective concentration: 1020 nM
Beside the measured number, compound 3's estimate is 6.8-fold (0.83 log units) below it; the whole stated range lies below it.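

In this assay, the position on an amine nitrogen in a ring proves sensitive to the group it carries: 5-isopropyl-1,3,4-oxadiazol-2-yl in place of 5-methoxypyrimidin-2-yl gives a 17-fold higher number from compound 1 to compound 3 (1.23 log units; beyond the scatter). Among these compounds, this is the first sized change at this position, and it shows that the shared core does not hold its activity whichever of these two groups is attached. The exchange of one ring isomer for the other cannot be read, as compound 2 has no number, and no measurement shown bears on why the number rises.

From the compounds shown here alone, whether the 5-isopropyl-1,2,4-oxadiazol-3-yl group of compound 2 would sit nearer to compound 1 or to compound 3 therefore stays open, and so does the question of how much of the step belongs to the isopropyl group and how much to the ring that carries it. A 5-methyl-1,3,4-oxadiazol-2-yl group, a 5-tert-butyl-1,3,4-oxadiazol-2-yl group or a 5-isopropylpyrimidin-2-yl group at the same place would bear on that question, but none of them is among the compounds shown.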